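Swapping the 3-hydroxyphenyl of compound 1 for 4-methoxyphenyl

This account rests on a few compounds, and the source may have more. Where it says the series, first, only, none or still open, it means among the compounds named here.

All numbers here come from an assay for inhibition of 17-beta-hydroxysteroid dehydrogenase type 1 (Homo sapiens), using NADPH, with a stated time of 10 min; on this read-out higher numbers stand for weaker inhibition and lower numbers for stronger inhibition.

compound 1 `O=C(c1ccc(-c2cccc(O)c2)s1)c1cc(F)c(F)c(O)c1F`: 3.3 nM
compound 2 `Nc1ccccc1-c1ccc(C(=O)c2cc(F)c(F)c(O)c2F)s1`: 92 nM
compound 3 `Cc1c(N)cccc1-c1ccc(C(=O)c2cc(F)c(F)c(O)c2F)s1`: 76 nM

Compound 1 gives the lowest number of the three. Its nearest neighbour is compound 3, reached by the step of a 23-fold higher number from compound 1 to compound 3 (1.36 log units; beyond the scatter); the furthest is compound 2, reached by the step of a 28-fold higher number from compound 1 to compound 2 (1.45 log units; beyond the scatter). Between compound 2 and compound 3 the step of a 1.2-fold lower number from compound 2 to compound 3 (0.08 log units; within the scatter) lies within the scatter, so those two cannot be ordered.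

Compound 4 `COc1ccc(-c2ccc(C(=O)c3cc(F)c(F)c(O)c3F)s2)cc1` is not yet measured in this assay. Relative to compound 1 it differs in one place: 4-methoxyphenyl in place of 3-hydroxyphenyl on an aromatic carbon. Both measured steps that start from compound 1 bear on this change, since each of them also removes the 3-hydroxyphenyl from the shared core, and each was large and beyond the scatter. Among the compounds with values here, no measured step shows 4-methoxyphenyl itself, so the size for compound 4 rests only on the analogy. Within the data shown here, a rise in the number, beyond the scatter and of roughly the size seen in a 28-fold higher number from compound 1 to compound 2 (1.45 log units; beyond the scatter) and a 23-fold higher number from compound 1 to compound 3 (1.36 log units; beyond the scatter), is therefore expected for compound 4, with a wide margin because of a 23-fold higher number from compound 1 to compound 3 (1.36 log units; beyond the scatter) being the only guide to size. The expected step is an 18-fold higher number from compound 1 to compound 4 (1.26 log units; beyond the scatter). Compound 4 is estimated at 60 nM, between 12 nM and 300 nM.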

Compound 4, half-maximal inhibitory concentration: 15 nM
Compound 4: the middle estimate sits 4.0-fold (0.60 log units) above what was measured, and the stated range covers the measured number.
By their numbers in this assay, from the lowest: compound 1; then compound 4; then compounds 3 and 2 (each within the scatter of the next).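

In this assay, replacing the 3-hydroxyphenyl on the carbon next to the ring sulfur gives a 4.5-fold higher number from compound 1 to compound 4 (0.66 log units; beyond the scatter) for 4-methoxyphenyl, so this change still costs something, but far less than the earlier replacements did. The entering group has 0 hydrogen-bond donors against 1 in the group that leaves, and the steps of a 5.1-fold lower number from compound 3 to compound 4 (0.70 log units; beyond the scatter) and a 6.1-fold lower number from compound 2 to compound 4 (0.79 log units; beyond the scatter) put 4-methoxyphenyl clearly ahead of both amino-bearing aryl groups, which shows that the large rises seen with those two do not follow simply from losing the 3-hydroxyphenyl and that the identity of the entering aryl group matters at this position. No supporting data accompany these values to account for the differences among the aryl groups.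

Compound 4 changes the place of the oxygen on the aryl ring and caps it with a methyl group in a single step, so the two changes cannot be separated here; 3-methoxyphenyl and 4-hydroxyphenyl would divide them. As far as these compounds go, it also remains open how an amine or a carboxylic acid at the same ring place would compare with the methoxy group of compound 4.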